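Acyl chain extension on the hydroxy-lactone series

The source may report more compounds than this note shows. Statements on the series, on what has been measured and on what is new or still open speak of the compounds shown alone.

The three measured compounds share one core bearing an alkyl chain on the saturated ring carbon and an acyl group on the enol side. Compound 1 `CCCCCCCC[C@@H]1CC(O)=C(C(=O)CCC)C(=O)O1` gives 30 ug/mL in an ADME assay on HepG2 cells (Homo sapiens) for cytotoxicity, read by XTT assay, with a stated time of 48 h; a higher number here means that more compound is tolerated, a lower number that less compound is tolerated. Compound 2 `CCCCCCCCCC[C@@H]1CC(O)=C(C(=O)CCC)C(=O)O1` carries ethyl in place of hydrogen on a saturated chain carbon, eight bonds along the chain from a saturated ring carbon; in this assay compound 2 gives 25 ug/mL, and the step of a 1.2-fold lower number from compound 1 to compound 2 (0.08 log units; within the scatter) is reported as within the scatter. Compound 3 `CCCCCCCCC[C@@H]1CC(O)=C(C(=O)CC)C(=O)O1` gives 50 ug/mL in this assay; the difference between its core and the core of compound 1 is not broken down here, and its values against compound 1 and compound 2 both sit within the scatter.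

Compound 4 `CCCCCCCCC[C@@H]1CC(O)=C(C(=O)CCCC)C(=O)O1` is not yet measured. Relative to compound 3 it carries ethyl in place of hydrogen on a saturated chain carbon, two bonds along the chain from a carbonyl carbon. This is the same kind of change as that from compound 1 to compound 2, but the place differs: there the ethyl entered eight bonds along the chain from a saturated ring carbon, here it enters two bonds along the chain from a carbonyl carbon.

For compound 4 the step is expected to be small, a 1.3-fold lower number from compound 3 to compound 4 (0.10 log units; within the scatter), beside the earlier 1.2-fold lower number from compound 1 to compound 2 (0.08 log units; within the scatter), because compound 1 to compound 2 shows a 1.2-fold lower number from compound 1 to compound 2 (0.08 log units; within the scatter) for the same kind of change. Among the measured compounds shown here, the expectation rests on only that one step, made at a different place. Compound 4 is therefore estimated at 40 ug/mL in this assay, with a range from 20 ug/mL to 80 ug/mL.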

Compound 4, half-maximal cytotoxic concentration: 36 ug/mL
The estimate for compound 4 lay 1.1-fold (0.05 log units) above the measured number; measured number inside the range.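

In this assay, ethyl in place of hydrogen on a saturated chain carbon, two bonds along the chain from a carbonyl carbon, gives a 1.4-fold lower number from compound 3 to compound 4 (0.14 log units; within the scatter), and the comparison with the earlier step on another core reads: the same change on two cores in this assay, a 1.2-fold lower number (0.08 log units; within the scatter) from compound 1 to compound 2 and a 1.4-fold lower number (0.14 log units; within the scatter) from compound 3 to compound 4, 1.2-fold (0.06 log units) apart, within the scatter of two such steps

Across these two pairs, the change carries from one core to the other without any step or gap leaving the scatter, so the series gives no sign here that the core alters what this change does. This does not establish a real effect of the change in either direction, since each step is itself within the scatter, and two pairs are too few to support a rule for the series; the pairs also differ in the place of the change as well as in the core, so those two factors cannot be separated.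

Every compound shown carries only saturated carbon chains on the shared core, so it remains open whether a much longer chain, or an amine or a carboxylic acid on either chain, would produce a step beyond the scatter. Also open, from the compounds shown here alone, is whether the agreement between the two steps would hold in any readout other than this assay.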